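Lengthening the Chain on the Ring Amine

The source may hold more compounds than are shown below. What is called first, only, known or untested is meant among the compounds shown, and "the series" means these compounds.

Two measured compounds share one core and differ in the group on the amine nitrogen in the ring. In a functional assay (strain AB) with Danio rerio as the target, read by microscopy, with a stated time of 1 h (on this read-out lower numbers stand for an effect already at smaller amounts and higher numbers for an effect only at larger amounts of compound), compound 1 `C[N+]1(CC2CCC2)CCc2c(sc(NC(=O)Nc3ccc(Cl)cc3)c2C(N)=O)C1` gives 210 nM. In this assay compound 2 `CC(C)(C)CN1CCc2c(sc(NC(=O)Nc3ccc(Cl)cc3)c2C(N)=O)C1` gives 5560 nM, the highest number of the two, and its gap to compound 1 lies beyond the usual scatter. Compound 3 `CC(C)(C)OC(=O)CCCN1CCc2c(sc(NC(=O)Nc3ccc(Cl)cc3)c2C(N)=O)C1` is the untested neighbour of compound 2: 2-(tert-butoxycarbonyl)ethyl in place of tert-butyl on a saturated chain carbon bound to an amine nitrogen in a ring. Within the data shown here, no measured pair shows this exact change, so its direction cannot be read from the data; the only hint is that compound 1 and compound 2 show the group on the ring amine can shift the number widely. A modest step from compound 2 to compound 3 of a 1.9-fold lower number from compound 2 to compound 3 (0.27 log units; within the scatter) toward a lower number is expected. Compound 3 is estimated at 3000 nM, with a range from 700 nM to 13000 nM.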

Compound 3, half-maximal effective concentration: 560 nM
Beside the measured number, compound 3's estimate is 5.4-fold (0.73 log units) above it, outside the stated range (below it).
By their numbers in this assay, from the lowest: compound 1; then compound 3; then compound 2.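

Replacing tert-butyl with 2-(tert-butoxycarbonyl)ethyl on a saturated chain carbon bound to an amine nitrogen in a ring gives, in this assay, a 9.9-fold lower number from compound 2 to compound 3 (1.00 log units; beyond the scatter). This shows that the position accepts a much larger group, with 9 heavy atoms in place of 4 and 2 hydrogen-bond acceptors in place of 0, and that the number falls rather than rises with this change. Nothing available explains why the number falls. The chain, the carbonyl and the tert-butyl end all change together in this step, so the compounds shown leave open which of them matters. A carboxylic acid in place of the tert-butyl ester, or a simple unbranched alkyl chain of the same length, would help to separate these parts.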